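This account rests on a few compounds, and the source may have more. Where it says the series, first, only, none or still open, it means among the compounds named here.

In a functional assay on NCI-H522 cells (Homo sapiens) for inhibition, read by sulforhodamine B assay, with a stated time of 48 h, tested at 10 uM (on this read-out lower numbers stand for less inhibition of growth and higher numbers for more inhibition of growth at the one concentration tested), compound 3 (`Clc1ccc(-c2cn3nc(-c4ccccc4)nc3s2)cc1`) gives 29%. Compound 2 (`COc1cc(-c2nc(N)n(CC(=O)Nc3ccc(/C(C)=N\O)cc3)n2)cc(OC)c1OC`) gives 29.2%, within the scatter of compound 3, while compound 1 (`COc1ccc(-c2nc3sc(-c4ccccc4)cn3n2)cc1`) gives 70%, a gap beyond the scatter. Compound 4 (`COc1ccc(-c2nc3sc(-c4ccc(Cl)cc4)cn3n2)cc1`) is compound 3 with one change: methoxy in place of hydrogen on an aromatic carbon. For the measured compounds named here, no measured pair isolates this change, so the size of the step remains uncertain. Compound 1 also carries a methoxy and gives 70%, but it differs from compound 3 in more than one place. A rise beyond the scatter is therefore expected in this assay, and the estimated step is a number 23 percentage points higher from compound 3 to compound 4 (beyond the scatter). For compound 4 the estimated value is 52%, with an expected range from 30% to 78%.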

Compound 4, percent growth inhibition at one concentration: 39%
Compound 4: middle estimate off by 13 percentage points, on the high side; low and high end bracket the measured number.
By their numbers in this assay, from the lowest: compounds 3, 2 and 4 (each within the scatter of the next); then compound 1.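

With the chloro already present, methoxy in place of hydrogen on an aromatic carbon gives a number 10 percentage points higher from compound 3 to compound 4 (within the scatter) in this assay and so moves the number no further than the scatter. With the methoxy already present, chloro in place of hydrogen on an aromatic carbon gives a number 31 percentage points lower from compound 1 to compound 4 (beyond the scatter) as a large drop, so the effect of a change here depends on which group is already there. Nothing at hand explains either step.

On these data alone, whether an amine or a carboxylic acid at this place would behave like methoxy remains open, as does the size of the methoxy step on a core without the chloro.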